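Dichlorinated bromophenyl sulfonamide: expected affinity of compound 4

The source may report more compounds than this note shows. Statements on the series, on what has been measured and on what is new or still open speak of the compounds shown alone.

Going by the values given here, compound 1 `COc1ccc(S(=O)(=O)Nc2cccc(Br)c2)cc1N1CCNCC1` gives 1.26 nM in an assay on isolated protein for binding affinity to 5-hydroxytryptamine receptor 6 (Homo sapiens) (on this read-out lower numbers stand for stronger inhibition and higher numbers for weaker inhibition), the second highest of the three numbers measured so far. Compound 2 `COc1ccc(S(=O)(=O)Nc2cc(Br)cc(Br)c2)cc1N1CCNCC1` gives 0.501 nM, and compound 3 `COc1ccc(S(=O)(=O)Nc2cc(Cl)cc(Br)c2Cl)cc1N1CCNCC1` gives 2 nM. The measured steps are a 2.5-fold lower number from compound 1 to compound 2 (0.40 log units; beyond the scatter), a 1.6-fold higher number from compound 1 to compound 3 (0.20 log units; within the scatter) and a 4.0-fold higher number from compound 2 to compound 3 (0.60 log units; beyond the scatter). Compound 4 `COc1ccc(S(=O)(=O)Nc2cc(Br)cc(Cl)c2Cl)cc1N1CCNCC1` is not yet measured; its change from compound 1 is 5-bromo-2,3-dichlorophenyl in place of 3-bromophenyl on a sulfonamide nitrogen. The step of a 1.6-fold higher number from compound 1 to compound 3 (0.20 log units; within the scatter) bears most directly, as it likewise exchanges the bromophenyl for a bromo-dichlorophenyl, and it stayed within the scatter. A similar outcome is therefore expected here, with the step of a 1.3-fold higher number from compound 1 to compound 4 (0.10 log units; within the scatter) expected to remain within the scatter. For compound 4 the estimate is 1.6 nM, with a range from 0.7 nM to 3.5 nM.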

Compound 4, inhibition constant: 3.98 nM
Compound 4: the middle estimate sits 2.5-fold (0.40 log units) below what was measured; measured number outside the range, above it.
By their numbers in this assay, from the lowest: compound 2; then compounds 1, 3 and 4 (each within the scatter of the next, the first and the last beyond it).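

In this assay, exchanging 3-bromophenyl for a bromo-dichlorophenyl group now gives a step beyond the scatter, a 3.2-fold higher number from compound 1 to compound 4 (0.50 log units; beyond the scatter), whereas a 1.6-fold higher number from compound 1 to compound 3 (0.20 log units; within the scatter) stayed within it. Even so, a 2.0-fold higher number from compound 3 to compound 4 (0.30 log units; within the scatter) leaves the two bromo-dichlorophenyl groups unseparated, so no effect of halogen placement on the ring is shown. The largest gap among these compounds is a 7.9-fold higher number from compound 2 to compound 4 (0.90 log units; beyond the scatter), and it favours the 3,5-dibromophenyl group over the 5-bromo-2,3-dichlorophenyl group.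

On these data alone, how an amine or a carboxylic acid on this aromatic ring would read remains open. No measurement at hand accounts for these steps.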